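Moving One Chlorine on a Dichlorophenyl Ring

This account rests on a few compounds, and the source may have more. Where it says the series, first, only, none or still open, it means among the compounds named here.

In a functional assay on HL-60 cells (Homo sapiens) for inhibition, read by MTT assay, with a stated time of 48 h, tested at 10 uM (on this read-out higher numbers stand for more inhibition of growth at the one concentration tested and lower numbers for less inhibition of growth), three compounds with a shared core have results so far. Compound 1 `Cc1cc(=O)c2c(O)c(CN3CCC(Cc4ccccc4)CC3)c(O)c([C@H]3CCN(C)C[C@H]3O)c2o1` reaches 28% and compound 2 `Cc1cc(=O)c2c(O)c(CN3CC(O)CC3C(=O)O)c(O)c([C@H]3CCN(C)C[C@H]3O)c2o1` reaches 28% on this read-out, the same number with two different side groups. Compound 3 `Cc1oc2c([C@H]3CCN(C)C[C@H]3O)c(O)cc(O)c2c(=O)c1C(O)c1c(Cl)cccc1Cl` gives 14% and stands lowest of the three, a gap to each of the others that lies beyond the usual scatter.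

Compound 4 `Cc1oc2c([C@H]3CCN(C)C[C@H]3O)c(O)cc(O)c2c(=O)c1C(O)c1cccc(Cl)c1Cl` has the same atoms as compound 3, joined differently: 2,3-dichlorophenyl in place of 2,6-dichlorophenyl on a saturated chain carbon bound to an aromatic carbon and an oxygen on a saturated carbon. In words, it carries 2,3-dichlorophenyl in place of 2,6-dichlorophenyl on a saturated chain carbon bound to an aromatic carbon and an oxygen on a saturated carbon. For the measured compounds named here, no measured pair here differs in one place only, so the data do not show what such a change does. The best guide is compound 3 at 14% as the closest relative. The expected step is a number 4 percentage points higher from compound 3 to compound 4 (within the scatter) in this assay and this small upward move stays within the usual scatter. For compound 4 the estimated value is 18% with an expected range from 5% to 35% for a measurement of this kind.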

Compound 4, percent growth inhibition at one concentration: 12%
For compound 4 the middle estimate is 6 percentage points above the measured one, within the range that was stated.
By their numbers in this assay, from the lowest: compounds 4 and 3 (each within the scatter of the next); then compounds 1 and 2 (each within the scatter of the next).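

Replacing 2,6-dichlorophenyl with 2,3-dichlorophenyl on a saturated chain carbon bound to an aromatic carbon and an oxygen on a saturated carbon gives a number 2 percentage points lower from compound 3 to compound 4 (within the scatter) in this assay. For the compounds shown here, this is the first pair here that differs in one place only, and it gives a direct reading of a change that the earlier comparisons could not isolate: moving one chlorine around the phenyl ring, with the same atoms in both compounds, does not separate compound 3 from compound 4 on this read-out at the single concentration tested. No measurement shown here bears on the reason for this result.

From the compounds shown here alone, the pair explores only these two dichlorophenyl groups, so it remains open whether a different group at this place, such as an unsubstituted phenyl, a 4-methoxyphenyl or a phenyl ring carrying an amine or a carboxylic acid, would give a number beyond the usual scatter from that of compound 3. Going by these compounds, it is also open whether compound 3 and compound 4 would still read alike at other concentrations or in other cell types.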